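The source may hold more compounds than are shown below. What is called first, only, known or untested is meant among the compounds shown, and "the series" means these compounds.

Measured in a functional assay on a cell-free system (plasma, Homo sapiens), with a stated time of 3 min; a higher number here means a weaker inhibitor, a lower number a stronger inhibitor:
- compound 1 `O=C(NCc1cc(Cl)ccc1-n1cnnn1)[C@@H]1C[C@@H]2C[C@@H]2N1C(=O)[C@H](O)C1CCCCC1`: 600 nM
- compound 2 `CC(C)(C)[C@@H](O)C(=O)N1[C@@H]2C[C@@H]2C[C@H]1C(=O)NCc1cc(Cl)ccc1-n1cnnn1`: 1100 nM

Half-maximal inhibitory concentration is the read-out, and a lower number means a stronger inhibitor. Compound 2 gives 1100 nM and compound 1 gives 600 nM. These two values lie within the usual scatter of each other, so the assay does not separate them.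

Compound 3 `CC(C)(C)[C@@H](O)C(=O)N1[C@H](C(=O)NCc2cc(Cl)ccc2-n2cnnn2)C[C@@H]2C[C@@H]21` is built from the same atoms and bonds as compound 2, and only its three-dimensional arrangement differs: the two compounds have the same atoms and bonds and differ only in configuration as drawn: 2 of 4 stereo elements differ; a stereocentre at a saturated ring carbon is drawn R in compound 2 and S in compound 3; a stereocentre at a saturated ring carbon is drawn R in compound 2 and S in compound 3. Two saturated ring carbons are drawn R in compound 2 and S in compound 3.

Among the measured compounds shown here, no measured pair here shows what such a change does, so this expectation is uncertain. A moderately higher number, meaning a somewhat weaker inhibitor, is expected in this assay, and the estimated change is a 1.8-fold higher number from compound 2 to compound 3 (0.26 log units; within the scatter). The estimated value for compound 3 is 2000 nM, with an expected range of 500 nM to 9000 nM.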

Compound 3, half-maximal inhibitory concentration: 1500 nM
Beside the measured number, compound 3's estimate is 1.3-fold (0.12 log units) above it; measured number inside the range.
By their numbers in this assay, from the lowest: compounds 1, 2 and 3 (each within the scatter of the next, the first and the last beyond it).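

Turning two saturated ring carbons from R to S gives a 1.4-fold higher number from compound 2 to compound 3 (0.13 log units; within the scatter) in this assay and so this change of configuration is not resolved by the assay. Putting tert-butyl in place of cyclohexyl does go beyond the scatter, with a 2.5-fold higher number from compound 1 to compound 3 (0.40 log units; beyond the scatter) as a modest step, so on this evidence the chain group registers more clearly than the ring configuration. The first of these two steps is a clean comparison of configuration alone, and it rests on one plain point: the fact that compounds 2 and 3 differ only in the configuration as drawn.

Both ring carbons change together here, which leaves open what either one does alone. Also open, on these data alone, is how a phenyl group or a longer chain would behave in place of tert-butyl and cyclohexyl, and how an amine would behave in place of the hydroxyl group.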